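Dropping the Amino Group from a Chloropurine Alkylator

The source may hold more compounds than are shown below. What is called first, only, known or untested is meant among the compounds shown, and "the series" means these compounds.

Of the compounds shown here, two have been measured for growth inhibition of a glioblastoma-derived cell line in a functional assay on SF-539 cells (Homo sapiens) for cytotoxicity, read by sulforhodamine B assay, with a stated time of 48 h; on this read-out higher numbers stand for weaker inhibition of growth and lower numbers for stronger inhibition of growth. Compound 1, `ClCc1cccc(Cn2cnc3c(Cl)nc(Cl)nc32)c1`, carries two chloro groups on its core and gives 14100 nM. Compound 2, `Nc1nc(Cl)c2ncn(Cc3ccccc3CCl)c2n1`, has an amino group in place of one chloro and a different arrangement of the chloromethyl-bearing benzyl group; in this assay compound 2 gives 38000 nM, the highest of the two numbers, and the gap to compound 1 lies beyond the usual scatter.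

Compound 3, `ClCc1ccccc1Cn1cnc2c(Cl)ncnc21`, has not yet been measured. It differs from compound 2 in one place: hydrogen in place of amino on an aromatic carbon. Compound 1 and compound 2 differ in more than one place, so their two values alone cannot show what removing the amino group does. The step from compound 2 to compound 3 is therefore expected to be modest, with no clear direction beyond the scatter, estimated as a 1.3-fold lower number from compound 2 to compound 3 (0.10 log units; within the scatter). In this assay compound 3 is expected to give about 30000 nM, within a range from 8000 nM to 110000 nM.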

Compound 3, concentration for total growth inhibition: 24000 nM
Compound 3: the middle estimate sits 1.3-fold (0.10 log units) above what was measured; measured number inside the range.
By their numbers in this assay, from the lowest: compounds 1, 3 and 2 (each within the scatter of the next, the first and the last beyond it).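

In this assay, among these compounds, the step of a 1.6-fold lower number from compound 2 to compound 3 (0.20 log units; within the scatter) is the first change in a single place that can be read: hydrogen takes the place of amino on an aromatic carbon between two ring nitrogen atoms. Compounds 1 and 2 differ in more than one place, so they could not isolate this position, whereas this pair shows that removing the amino group, with its one nitrogen, leaves the number within the usual scatter. For this one pair, then, the amino group is not needed to hold growth inhibition at this level, although a single pair sets no rule for the series, and no measurement shown here offers an explanation for the size of the step.

Going by these compounds, what other groups would do at this carbon remains open, since a methyl group, a hydroxyl group or a larger amine might move the number further than hydrogen does. No two compounds shown differ only in the arrangement of the chloromethyl-bearing benzyl group, so the contribution of that arrangement also remains unresolved, as does whether the small amino step would hold with a different arrangement.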